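Swapping a Small Ether Cap for a Benzyl Group

The source may report more compounds than this note shows. Statements on the series, on what has been measured and on what is new or still open speak of the compounds shown alone.

Of the compounds shown here, two sharing a bicyclic amine core have been tested in an assay on HEK293 cells for antagonist activity at Nicotinic acetylcholine receptor alpha-4/beta-2 (Mus musculus), read by FLIPR, using a membrane potential dye; a higher number here means a weaker inhibitor, a lower number a stronger inhibitor. Compound 1 `CO[C@H]1CC[C@H]2CCN(C)[C@H]2C1` gives in this assay > 300000 nM, which is a limit of the assay rather than a number. Going by the values given here, compound 2 `CO[C@H]1CC=C2CCN(C)[C@H]2C1` gives in this assay 30000 nM, the only genuine number so far. The remaining result, that of compound 1, sits at a limit (the limit of > 300000 nM in this assay, at which 1 of the 2 values shown sits). Compound 3 `CN1CCC2=CC[C@H](OCc3ccccc3)C[C@@H]21` keeps everything of compound 2 except one change: phenyl in place of hydrogen on a saturated chain carbon bound to an oxygen on a saturated carbon. No pair already measured differs in only this way, so the size of the step cannot be read off from the shown numbers. The expectation is a moderate gain in potency, with the step from compound 2 to compound 3 estimated at a 3.0-fold lower number from compound 2 to compound 3 (0.48 log units; beyond the scatter). Compound 3 is therefore expected to give in this assay 10000 nM, with a likely range from 2000 nM to 100000 nM.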

Compound 3, half-maximal inhibitory concentration: > 300000 nM
Compound 3: no number, only a limit (the forecaster's own chance of this, stated with the estimate: 20%); middle value at least 30-fold (1.47 log units) away from the limit.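

In this assay, phenyl in place of hydrogen on a saturated chain carbon bound to an oxygen on a saturated carbon gives an at least 10-fold higher number from compound 2 to compound 3 (1.00 log units; beyond the scatter), the opposite direction from a gain in potency. At this position, then, the small ether cap of compound 2 cannot be exchanged for the benzyl group without losing the modest inhibition that compound 2 shows. The step has only a minimum size, not an exact one, since compound 3 reaches a limit of the assay rather than a number: the limit of > 300000 nM in this assay, at which 2 of the 3 values shown sit.

The compounds shown leave open whether a single methyl or an ethyl on that same carbon would keep the inhibition of compound 2 or lose it as well. They also leave open how a free hydroxyl in place of the whole ether would compare.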